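The source may report more compounds than this note shows. Statements on the series, on what has been measured and on what is new or still open speak of the compounds shown alone.

In a functional assay on MCF7 cells (Homo sapiens) for cytotoxicity, read by MTT assay, with a stated time of 24 h (a higher number here means a weaker inhibitor, a lower number a stronger inhibitor), compound 1 `Cc1ccc(Cc2cn3cc(Cl)ccc3nc2=O)cc1` gives > 1000000 nM, which is a limit of the assay and not a number. Compound 2 `O=c1nc2ccc(Cl)cn2cc1Cc1ccc(F)cc1` gives 10400 nM, the lower of the two actual numbers, and compound 3 `O=c1nc2ccc(Cl)cn2cc1Cc1ccc(Oc2nc(Cl)c(Cl)cc2Cl)cc1` gives 96900 nM. Compound 4 `O=c1nc2ccc(Cl)cn2cc1Cc1ccc([N+](=O)[O-])cc1` carries nitro in place of the fluoro of compound 2: nitro in place of fluoro on an aromatic carbon. Among the measured compounds shown here, one measured step bears on this change, an at least 96-fold lower number from compound 1 to compound 2 (1.98 log units; beyond the scatter), as it also swaps a group on an aromatic carbon. Such a swap can clearly matter, although the size of that step rests on (the limit of > 1000000 nM in this assay, at which 1 of the 3 values shown sits). Compound 2 also stays lower than compound 3. A moderate rise is therefore expected in this assay, an estimated 2.9-fold higher number from compound 2 to compound 4 (0.46 log units; beyond the scatter). For compound 4 the estimate is 30000 nM, with an expected range of 4000 nM to 300000 nM.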

Compound 4, half-maximal inhibitory concentration: > 1000000 nM
Compound 4 ended at the assay's limit; the forecaster's own chance of this, stated with the estimate: 15%; middle value at least 33-fold (1.52 log units) from the limit.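

In this assay the change on this aromatic carbon gives an at least 96-fold higher number from compound 2 to compound 4 (1.98 log units; beyond the scatter) and so is not a small adjustment. Nitro and methyl now both leave the compound at the assay's limit, whereas fluoro in compound 2 gives a real number, and so does the larger group of compound 3. On these data alone, compound 1 and compound 4 both stand at a limit, so the step between them cannot be read, and the true size of the rise also stays unknown: the limit of > 1000000 nM in this assay, at which 2 of the 4 values shown sit.

As far as these compounds go, whether an amine or a carboxylic acid at this position would behave more like fluoro or more like nitro remains open.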